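Paw edema inhibition: chloro step from compound 3 to compound 4

The source may hold more compounds than are shown below. What is called first, only, known or untested is meant among the compounds shown, and "the series" means these compounds.

Measured in a functional assay on the whole organism for inhibition, with Rattus norvegicus as the target, read by paw edema, with a stated time of 4 h, at a dose of 70 mg/kg by the oral route; a higher number here means more inhibition at the dose given (going by the name of the read-out), a lower number less inhibition:
compound 1, `c1ccc(-c2nn3c(-c4ccncc4)nnc3s2)cc1`: 66.4%
compound 2, `c1ccc(Oc2nn3c(-c4ccncc4)nnc3s2)cc1`: 63.6%
compound 3, `Clc1ccccc1-c1nnc(-c2ccncc2)o1`: 37.7%

Compound 3 stands lowest of the three; the nearest number is that of compound 2, and its gap to compound 2 as well as to compound 1 lies beyond the scatter. Among the measured compounds shown here, the single measured step, a number 2.8 percentage points lower from compound 1 to compound 2 (within the scatter), concerns phenoxy in place of phenyl and stays within the scatter. Compound 4, `Clc1ccc(-c2nnc(-c3ccncc3)o2)c(Cl)c1`, differs from compound 3 by chloro in place of hydrogen on an aromatic carbon. For the measured compounds named here, no measured step concerns a chloro entering for hydrogen, so nothing bears on this change directly, and the one step seen was within the scatter. The change is therefore expected to give a number 2.3 percentage points higher from compound 3 to compound 4 (within the scatter), nothing beyond the scatter. Compound 4 is estimated at 40%, within a range from 25% to 55%.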

Compound 4, a percentage reported as inhibition, in the whole organism at one dose (the size of the read-out at that dose, not a potency): 84%
Compound 4: the middle estimate sits 44 percentage points below what was measured, and the stated range ends below it.
By their numbers in this assay, from the lowest: compound 3; then compounds 2 and 1 (each within the scatter of the next); then compound 4.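

In this assay, chloro entering on the six-membered aromatic ring of carbon only, para to a large group and meta to the existing chloro, gives a number 46.3 percentage points higher from compound 3 to compound 4 (beyond the scatter). This position therefore responds strongly to a single added atom, unlike the phenoxy for phenyl exchange, a number 2.8 percentage points lower from compound 1 to compound 2 (within the scatter). No available data account for the size of this step.

On these data alone, whether the rise is specific to chloro remains open, as a methyl, methoxy or amine at this place would test. Also open, as far as these compounds go, is whether chloro here needs the existing chloro.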